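A few compounds are considered here, and "the series" means these few. Any claim that something is new, unique, unknown or untested is made for them only; others in the source may bear on it.

Three compounds share one core and differ only in the aryl group on the sulfonyl sulfur. Compound 1 `O=S(=O)(NC1=NCCN1C(=S)SN1CCn2c1nsc2=S)c1ccccc1` carries phenyl; in a functional assay on KYSE-510 cells (Homo sapiens) for antiproliferative activity, read by crystal violet staining, with a stated time of 96 h (on this read-out lower numbers stand for stronger inhibition of growth and higher numbers for weaker inhibition of growth), compound 1 gives >= 20000 nM, a limit of the assay rather than a number. Compound 2 `COc1ccc(S(=O)(=O)NC2=NCCN2C(=S)SN2CCn3c2nsc3=S)cc1` likewise returns only a limit, >= 20000 nM. Compound 3 `COc1ccc(OC)c(S(=O)(=O)NC2=NCCN2C(=S)SN2CCn3c2nsc3=S)c1` also stands at a limit, >= 20000 nM, so its place on the numbers shown is known only as that limit. The steps a step that the two limits leave unreadable from compound 1 to compound 2, a step that the two limits leave unreadable from compound 1 to compound 3 and a step that the two limits leave unreadable from compound 2 to compound 3 are therefore unreadable, as the limit of >= 20000 nM in this assay, at which 3 of the 3 values shown sit, records. Compound 4 `O=S(=O)(NC1=NCCN1C(=S)SN1CCn2c1nsc2=S)c1ccc(Br)cc1` changes the aryl once more: 4-bromophenyl in place of 2,5-dimethoxyphenyl on a sulfonyl sulfur. With no readable step to build on, compound 4 is expected to remain near the limit, an estimated 20000 nM with a range from 8000 nM to 50000 nM. The expected step of a number no higher from compound 3 to compound 4 (the limit leaves the size open) is thus estimated as none of readable size.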

Compound 4, concentration for 50% growth inhibition: >= 20000 nM
Compound 4 gave a limit, no number (the forecaster's own chance of this, stated with the estimate: 80%); the middle value sits exactly at the limit.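

Going by these compounds alone, compound 4 also returns only a limit, so no step from compound 1, compound 2 or compound 3 to compound 4 can be read: the limit of >= 20000 nM in this assay, at which 4 of the 4 values shown sit. The compounds shown leave open whether any aryl group on the sulfonyl sulfur of the shared core would give a number in this assay.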